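This account rests on a few compounds, and the source may have more. Where it says the series, first, only, none or still open, it means among the compounds named here.

In a functional assay on RAW264.7 cells (Mus musculus) for inhibition, read by Griess assay, with a stated time of 24 h (a higher number here means a weaker inhibitor, a lower number a stronger inhibitor), compound 1 `C=C1CC[C@@H]2[C@](C)(CO)[C@H](O)CC[C@@]2(C)[C@]1(O)CCC1=CCOC1=O` gives > 100000 nM, a limit of the assay and not a number. Compound 2 `C=C1CC[C@@H]2[C@](C)(CO)C(=O)CC[C@@]2(C)[C@]1(O)CCC1=CCOC1=O` gives a true number, 28400 nM. Compound 3 `C[C@@]1(CO)[C@H](O)CC[C@@]2(C)C(CCC3=CCOC3=O)=C(CO)CC[C@H]12` gives > 100000 nM, also a limit, so its place on the scale is not known more closely. Compound 4 `C[C@@]1(CO)[C@H](O)CC[C@@]2(C)C(CCC3=CCOC3=O)=C(C=O)CC[C@H]12` has formyl in place of hydroxymethyl on a double-bonded ring carbon of compound 3: formyl in place of hydroxymethyl on a double-bonded ring carbon. Within the data shown here, no measured step shows what this change does in this assay. Among the measured compounds shown here, the only guide to the size of the step is compound 2 at 28400 nM, so a moderate move towards stronger inhibition is expected. A reading at the limit of the assay remains possible for compound 4. The expected step is an at least 4.0-fold lower number from compound 3 to compound 4 (0.60 log units; beyond the scatter). Compound 4 is estimated at 25000 nM, with an expected range of 5000 nM to 100000 nM.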

Compound 4, half-maximal inhibitory concentration: > 100000 nM
Compound 4: a limit, no number (the forecaster's own chance of this, stated with the estimate: 30%); middle value at least 4.0-fold (0.60 log units) from the limit.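

Compound 3 and compound 4 both give a limit in this assay and not a number, so no step can be read between them. The compounds shown leave open what formyl in place of hydroxymethyl on a double-bonded ring carbon does to inhibition, with both readings resting on one limit: the limit of > 100000 nM in this assay, at which 3 of the 4 values shown sit.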